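Shifting the Methyl Group Around the Phenyl Ring

This account rests on a few compounds, and the source may have more. Where it says the series, first, only, none or still open, it means among the compounds named here.

Compound 1 `O=c1c2ccccc2[se]n1-c1nnc(-c2ccc(Br)cc2)s1` gives 39100 nM in a functional assay on A549 cells (Homo sapiens) for antiproliferative activity, read by CCK-8 assay, with a stated time of 48 h; on this read-out higher numbers stand for weaker inhibition and lower numbers for stronger inhibition.
Compound 2 `O=c1c2ccccc2[se]n1-c1nnc(-c2ccccc2Cl)s1` gives 10100 nM.
Compound 3 `Cc1cccc(-c2nnc(-n3[se]c4ccccc4c3=O)s2)c1` gives 14800 nM.

Compound 3 stands second highest of the three numbers, with compound 2 close by within the scatter and compound 1 further off, as a 2.6-fold lower number from compound 1 to compound 3 (0.42 log units; beyond the scatter) shows. Compound 4 `Cc1ccc(-c2nnc(-n3[se]c4ccccc4c3=O)s2)cc1` differs from compound 3 by 4-methylphenyl in place of 3-methylphenyl on an aromatic carbon. Going by the values given here, no measured step moves a methyl group along the ring; the steps of a 3.9-fold lower number from compound 1 to compound 2 (0.59 log units; beyond the scatter) and a 2.6-fold lower number from compound 1 to compound 3 (0.42 log units; beyond the scatter) both replace 4-bromophenyl. Among the compounds with values here, compound 1, the only other compound bearing a group named with a 4-position, carries the highest number, but its group is not a methyl. A small rise in this assay is therefore expected, a 1.5-fold higher number from compound 3 to compound 4 (0.17 log units; within the scatter), though it may stay within the scatter. Compound 4 is estimated at 22000 nM, between 9000 nM and 55000 nM.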

Compound 4, half-maximal inhibitory concentration: 13400 nM
The estimate for compound 4 lay 1.6-fold (0.22 log units) above the measured number; measured number inside the range.
By their numbers in this assay, from the lowest: compounds 2, 4 and 3 (each within the scatter of the next); then compound 1.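

Moving the methyl from 3-methylphenyl to 4-methylphenyl makes no readable difference in this assay and gives a 1.1-fold lower number from compound 3 to compound 4 (0.04 log units; within the scatter) on the same ring carbon. Compound 4 also sits level with the 2-chlorophenyl compound, with a 1.3-fold higher number from compound 2 to compound 4 (0.12 log units; within the scatter) and no order between them, while the direct swap from 4-bromophenyl to 4-methylphenyl gives a 2.9-fold lower number from compound 1 to compound 4 (0.47 log units; beyond the scatter) as a modest gain. Nothing measured here accounts for these numbers.

Open, going by these compounds, is where 2-methylphenyl would fall beside its two isomers. Also open, on these data alone, is whether an amine or a carboxylic acid on the phenyl ring would shift the number further.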